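Trimming the tert-butylamino side group to a hydroxy

A few compounds are considered here, and "the series" means these few. Any claim that something is new, unique, unknown or untested is made for them only; others in the source may bear on it.

Three pyrazine carbonylguanidines share one core and differ only in the group attached to it. Compound 1 `CC(C)(C)Nc1nc(N)c(C(=O)N=C(N)N)nc1Cl` carries a (tert-butyl)amino group; compound 3 `NC(N)=NC(=O)c1nc(Cl)c(NCC2CCCCC2)nc1N` carries a cyclohexylmethylamino group; compound 2 `NC(N)=NC(=O)c1nc(Cl)c(NCC2CCc3ccccc3C2)nc1N` carries a larger bicyclic group but has no reported result. In an assay for inhibition of acid-sensing ion channel 3 (Homo sapiens), read by patch clamp, tested at 20 uM (on this read-out higher numbers stand for more inhibition at the one concentration tested (going by the name of the read-out) and lower numbers for less inhibition), compound 1 gives 48%, and compound 3 gives 96%. In this assay compound 2 gives "not determined" (no result reported). Within the data shown here, on these numbers compound 1 stands lowest of the two values, with compound 3 the only neighbour, lying a number 48 percentage points higher from compound 1 to compound 3 (beyond the scatter).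

Compound 4 `NC(N)=NC(=O)c1nc(Cl)c(O)nc1N` is the next variation: hydroxy in place of (tert-butyl)amino on an aromatic carbon. Among the measured compounds shown here, only one measured step bears on this change, the one from compound 1 to compound 3, which swapped one group on the same nitrogen for another and raised inhibition by a large amount. The step to compound 4 runs the other way in kind, taking away the whole (tert-butyl)amino group and leaving a bare hydroxy. Nothing measured shows what the core does with so small a group in this position. Given that the single informative step rewarded a bigger group, the expectation for compound 4 is a drop in this assay, estimated as a number 33 percentage points lower from compound 1 to compound 4 (beyond the scatter), to about 15% with a range from 0% to 40%.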

Compound 4, a percentage reported as inhibition, at one concentration (the size of the read-out at that concentration, not a potency): 9%
For compound 4 the middle estimate is 6 percentage points above the measured one, and the stated range covers the measured number.
By their numbers in this assay, from the lowest: compound 4; then compound 1; then compound 3.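

In this assay, the change to hydroxy gives a number 39 percentage points lower from compound 1 to compound 4 (beyond the scatter), showing that this position is sensitive not only to swapping one group on the nitrogen for another, as the earlier step did, but also to removing the nitrogen and its carbons altogether. The fall comes with far fewer heavy atoms on the core, while the counts of hydrogen-bond donors and acceptors in the leaving and entering groups are the same, so those counts alone do not track the result in this pair. Nothing measured here explains why inhibition falls with this change.

Hydroxy differs from (tert-butyl)amino in two ways at once, since it loses the carbons and also puts oxygen where nitrogen stood, and this single step cannot separate those two changes. A plain amino group or a methylamino group would keep the nitrogen while shedding carbons, and a tert-butoxy group would keep the carbons while replacing the nitrogen with oxygen, so these would show which part of the change matters more.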